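Amine swap from compound 3 to compound 4: working notes

A few compounds are considered here, and "the series" means these few. Any claim that something is new, unique, unknown or untested is made for them only; others in the source may bear on it.

- Compound 1 `CC(C)=CCc1cc(C(=O)Nc2cc3ccc(OCCCNCC(C)C)c(C)c3oc2=O)ccc1O`: 1030 nM
- Compound 2 `COC(=O)CNCCCOc1ccc2cc(NC(=O)c3ccc(O)c(CC=C(C)C)c3)c(=O)oc2c1C`: 1060 nM
- Compound 3 `CC(C)=CCc1cc(C(=O)Nc2cc3ccc(OCCCNC(C)(C)c4ccccc4)c(C)c3oc2=O)ccc1O`: 960 nM

All three values come from a functional assay on SK-BR-3 cells (Homo sapiens) for antiproliferative activity; a higher number here means a weaker inhibitor, a lower number a stronger inhibitor. Compound 3 stands level with the other two compounds, with a 1.1-fold lower number from compound 1 to compound 3 (0.03 log units; within the scatter) and a 1.1-fold lower number from compound 2 to compound 3 (0.04 log units; within the scatter), both within the scatter.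

Going by the values given here, the next compound, compound 4 `CC(C)=CCc1cc(C(=O)Nc2cc3ccc(OCCCN(C)Cc4ccccc4)c(C)c3oc2=O)ccc1O`, has no measurement yet in this assay. Its change lies on a saturated chain carbon, three bonds along the chain from an oxygen on an aromatic ring: benzyl(methyl)amino in place of (1-methyl-1-phenylethyl)amino on a saturated chain carbon, three bonds along the chain from an oxygen on an aromatic ring.

The most relevant evidence is the two steps into compound 3, which alter the group on the same amine nitrogen: a 1.1-fold lower number from compound 1 to compound 3 (0.03 log units; within the scatter) and a 1.1-fold lower number from compound 2 to compound 3 (0.04 log units; within the scatter). The third step, a 1.0-fold higher number from compound 1 to compound 2 (0.01 log units; within the scatter), is also within the scatter. Among these three compounds, no change on the amine moved the value beyond the scatter, and none goes against this pattern. However, none of them carries benzyl(methyl)amino, so the evidence for this exact group is indirect. No step beyond the scatter is therefore expected in this assay, and no direction is favoured.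

The expected change is a 1.0-fold higher number from compound 3 to compound 4 (0.02 log units; within the scatter).

For compound 4 the estimate is 1000 nM, with an expected range of 500 nM to 2000 nM.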

Compound 4, half-maximal inhibitory concentration: 10700 nM
For compound 4 the middle estimate is 11-fold (1.03 log units) below the measured one; measured number above the stated range.
By their numbers in this assay, from the lowest: compounds 3, 1 and 2 (each within the scatter of the next); then compound 4.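

Working notes on the amine position: in this assay this position is not as flat as compounds 1 to 3 suggested, since benzyl(methyl)amino gives an 11-fold higher number from compound 3 to compound 4 (1.05 log units; beyond the scatter) and, against the other two amines, a 10-fold higher number from compound 1 to compound 4 (1.02 log units; beyond the scatter) and a 10-fold higher number from compound 2 to compound 4 (1.00 log units; beyond the scatter). Isobutylamino, ((methoxycarbonyl)methyl)amino and (1-methyl-1-phenylethyl)amino sit within the scatter of one another, while compound 4 alone stands apart, and the one-atom difference in heavy-atom count between the leaving and entering groups comes with this large step. Both compound 3 and compound 4 carry a six-membered aromatic ring of carbon only, so the presence of that ring does not separate them, whereas the hydrogen-bond donor count of the group falls from 1 to 0; no measurement shown explains the loss.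

The shift of the methyl group and the removal of the hydrogen on nitrogen are coupled in this single change, so the step cannot be assigned to either alone. A benzylamino group, which keeps that hydrogen, and a dimethylamino or N-methylisobutylamino group, which removes it without a benzyl group, would pull the two apart.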